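A few compounds are considered here, and "the series" means these few. Any claim that something is new, unique, unknown or untested is made for them only; others in the source may bear on it.

Measured in a functional assay on MCF7 cells (Homo sapiens) for cytotoxicity, read by fluorescence, with a stated time of 72 h; on this read-out higher numbers stand for weaker inhibition and lower numbers for stronger inhibition:
Compound 1 `Nc1nn(C(=O)c2ccc([N+](=O)[O-])cc2)c(N)c1/N=N/c1ccc(O)cc1`: > 25000 nM
Compound 2 `Cn1nc(N)c(/N=N/c2ccc(O)cc2)c1N`: > 100000 nM

Compound 2 stands at > 100000 nM in this assay, and this is a limit of the assay rather than a number. Compound 1 stands at > 25000 nM, which is also a limit. Within the data shown here, the two compounds do not form a pair that differs in one place, so no measured step is available to guide the next comparison.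

Compound 3 `CC(=O)n1nc(N)c(/N=N/c2ccc(O)cc2)c1N` keeps the core of compound 2 and changes one group, with acetyl in place of methyl on an aromatic nitrogen. Compound 1 also carries a carbonyl on an aromatic nitrogen and still gives only the limit of > 25000 nM, so a large gain is not expected from this change. In this assay, only a modest move toward stronger inhibition is expected, and the estimated step is an at least 2.0-fold lower number from compound 2 to compound 3 (0.30 log units; that floor lies within the scatter). The estimate for compound 3 is 50000 nM, with an expected range of 15000 nM to 150000 nM, and a result reported only as a limit is thought likely.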

Compound 3, half-maximal inhibitory concentration: 44900 nM
Estimate against measurement, compound 3: 1.1-fold (0.05 log units) above; low and high end bracket the measured number.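

Acetyl in place of methyl on an aromatic nitrogen brings an at least 2.2-fold lower number from compound 2 to compound 3 (0.34 log units; beyond the scatter) in this assay, which shows that this position responds to the change and gives the only number among the three compounds rather than a limit. Compound 2 stands at a limit and not at a number, so the size of this step is only a floor: the limit of > 100000 nM in this assay, at which 1 of the 3 values shown sits. Compound 1 also stands at a limit, so the step between compound 1 and compound 3, methyl in place of 4-nitrophenyl on a carbonyl carbon, cannot be read: the limit of > 25000 nM in this assay, at which 1 of the 3 values shown sits.

The compounds shown leave open whether the carbonyl itself matters on this nitrogen or whether a larger group without one, such as an ethyl or a longer chain, would move the number in the same way. They also leave open how far compound 3, at 44900 nM, would shift if a carboxylic acid took the place of one amino group on the shared core.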